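The source may report more compounds than this note shows. Statements on the series, on what has been measured and on what is new or still open speak of the compounds shown alone.

Measured compounds in an ADME assay on Vero cells (Chlorocebus sabaeus) for cytotoxicity, read by MTT assay, with a stated time of 72 h; on this read-out lower numbers stand for higher toxicity in this test and higher numbers for lower toxicity in this test:

compound 1 `COc1ccc([C@@H](O)COC(=O)/C=C/c2ccccc2)cc1OC` gives 5870 nM
compound 2 `COc1cccc([C@@H](O)COC(=O)/C=C/c2ccccc2)c1` gives 22300 nM
compound 3 `COc1ccc([C@H](O)COC(=O)/C=C/c2ccccc2)cc1` gives 33500 nM

Compound 3 stands at the highest number of the three in this assay; its gap to compound 2 is within the scatter, so no order between compound 2 and compound 3 is claimed, while its gap to compound 1 is beyond the scatter.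

One change is seen once in the measured set: from compound 1 to compound 2 the change is hydrogen in place of methoxy on an aromatic carbon and the step is a 3.8-fold higher number from compound 1 to compound 2 (0.58 log units; beyond the scatter).

Compound 4 `O=C(/C=C/c1ccccc1)OC[C@@H](O)c1ccccc1` is not yet measured. It comes from compound 3 by hydrogen in place of methoxy on an aromatic carbon. This is the same kind of change as that from compound 1 to compound 2, not the same change: in compound 1 the carbon that loses the methoxy is ortho to a methoxy group, in compound 3 it is not. The difference between the core of compound 1 and the core of compound 3 is not broken down here.

Among the compounds with values here, the expectation for compound 4 in this assay rests on the single measured step of this kind, a 3.8-fold higher number from compound 1 to compound 2 (0.58 log units; beyond the scatter), read with caution: the surroundings of the changed carbon are not the same. For compound 4 the expected step is a 1.8-fold higher number from compound 3 to compound 4 (0.25 log units; within the scatter), somewhat smaller than the measured one. Compound 4 is thus estimated at 60000 nM, with a likely range from 25000 nM to 150000 nM.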

Compound 4, half-maximal cytotoxic concentration: 39200 nM
Compound 4: the middle estimate sits 1.5-fold (0.18 log units) above what was measured; the measured number falls inside the stated range.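

In this assay, hydrogen in place of methoxy on an aromatic carbon gives a 1.2-fold higher number from compound 3 to compound 4 (0.07 log units; within the scatter), so no shift from this change can be claimed on the core of compound 3. Set beside the earlier step, the change does not carry over in size from one core to the other: the same change on two cores in this assay, a 3.8-fold higher number (0.58 log units; beyond the scatter) from compound 1 to compound 2 and a 1.2-fold higher number (0.07 log units; within the scatter) from compound 3 to compound 4, 3.2-fold (0.51 log units) apart, beyond the scatter of two such steps Two steps show that a result on one core in this series cannot simply be transferred to another, but they do not show which difference between the two cores or which feature of the surroundings of the changed carbon sets the size of the step, and they give no rule for a further core.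

The compounds shown carry only methoxy or hydrogen at the changed aromatic carbons, so it remains open how a halogen, an amine or a carboxylic acid at such a carbon would read in this test. The ester link and the unsubstituted phenyl ring of the acid part are also constant throughout, leaving open what an amide in place of the ester, or a substituent such as methoxy on that ring, would do.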